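Cyclopentyloxy in place of arylsulfanyl on the shared core

A few compounds are considered here, and "the series" means these few. Any claim that something is new, unique, unknown or untested is made for them only; others in the source may bear on it.

Three compounds on the shared core carry a measured value in a functional assay for inhibition of sodium/hydrogen exchanger (Oryctolagus cuniculus); a higher number here means a weaker inhibitor, a lower number a stronger inhibitor. Compound 1 `CCSc1cc(C)c(C(=O)N=C(N)N)cc1S(C)(=O)=O` gives 5.9 nM. Compound 2 `CCCSc1cc(C)c(C(=O)N=C(N)N)cc1S(C)(=O)=O` gives 6.8 nM. Compound 3 `Cc1cc(Sc2cccc(Cl)c2)c(S(C)(=O)=O)cc1C(=O)N=C(N)N` gives 37 nM, the highest of the three numbers; compound 2 is nearest and compound 1 furthest, both beyond the scatter.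

The steps among the measured compounds: a 1.2-fold higher number from compound 1 to compound 2 (0.06 log units; within the scatter); a 6.3-fold higher number from compound 1 to compound 3 (0.80 log units; beyond the scatter); a 5.4-fold higher number from compound 2 to compound 3 (0.74 log units; beyond the scatter). Replacing an alkyl on the sulfur by 3-chlorophenyl thus raised the number by a modest amount in both cases, while lengthening the alkyl did not move it beyond the scatter.

Compound 4 `Cc1cc(OC2CCCC2)c(S(C)(=O)=O)cc1C(=O)N=C(N)N` is not yet measured. Its change from compound 3: cyclopentyloxy in place of (3-chlorophenyl)sulfanyl on an aromatic carbon. Within the data shown here, no measured step covers oxygen in place of sulfur, nor a non-aromatic ring on that atom. Among the measured compounds shown here, the steps that bear on it are the two replacements of alkyl by 3-chlorophenyl, which went in one direction; a group with a non-aromatic ring of carbon only is closer to the alkyl cases, so a lower number than compound 3 is expected, though the unknown effect of the oxygen widens the range. Compound 4 is expected to give 12 nM in this assay, between 4 nM and 40 nM. The estimated step is a 3.1-fold lower number from compound 3 to compound 4 (0.49 log units; beyond the scatter).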

Compound 4, half-maximal inhibitory concentration: 27 nM
Estimate against measurement, compound 4: 2.3-fold (0.35 log units) below, and the stated range covers the measured number.
By their numbers in this assay, from the lowest: compounds 1 and 2 (each within the scatter of the next); then compounds 4 and 3 (each within the scatter of the next).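

Notes on the aromatic carbon ortho to a methylsulfonyl group: in this assay, cyclopentyloxy and (3-chlorophenyl)sulfanyl are not separated, the exchange giving a 1.4-fold lower number from compound 3 to compound 4 (0.14 log units; within the scatter), so an aromatic ring on sulfur and a non-aromatic ring on oxygen cannot be told apart at this position. Set against the open-chain groups, cyclopentyloxy gives a 4.0-fold higher number from compound 2 to compound 4 (0.60 log units; beyond the scatter) and a 4.6-fold higher number from compound 1 to compound 4 (0.66 log units; beyond the scatter), so among these four compounds the gap to ethylsulfanyl and propylsulfanyl, earlier seen only with 3-chlorophenyl, also appears with a group that carries no aromatic ring and no sulfur, and no compound shown goes against this. Nothing at hand accounts for these steps.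

In every step to compound 4 the linking atom and the group on it change together, so the part played by oxygen alone cannot be read; cyclopentylsulfanyl and ethoxy on the shared core would separate the two changes. Also open, from the compounds shown here alone, is how this position responds to a ring-bearing amine such as cyclopentylamino, or to a larger ring such as cyclohexyloxy.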